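The source may report more compounds than this note shows. Statements on the series, on what has been measured and on what is new or still open speak of the compounds shown alone.

Measured so far:
Compound 1, `O=C(NCc1ccc(C(=O)N2CCCCc3ccccc32)c(F)c1)Nc1c(F)cccc1F`: 180 nM
Compound 2, `COC(=O)CNC(=O)NCc1ccc(C(=O)N2CCCCc3ccccc32)cc1C`: 37 nM
Compound 3, `Cc1cc(C(=O)N2CCCCc3ccccc32)ccc1CNC(=O)N1CC(C(F)F)C[C@H]1C(=O)N(C)C`: 50 nM

In a functional assay on HEK293 cells for agonist activity at Vasopressin V2 receptor (Homo sapiens), read by a luciferase reporter and cAMP accumulation (on this read-out lower numbers stand for an effect already at smaller amounts and higher numbers for an effect only at larger amounts of compound), compound 3 gives 50 nM, the second highest of the three numbers. Its nearest neighbour is compound 2 with 37 nM, a gap that lies within the scatter; the furthest is compound 1 with 180 nM, a gap beyond the scatter. Compound 4, `COC(OC)C1C[C@@H](C(=O)N(C)C)N(C(=O)NCc2ccc(C(=O)N3CCCCc4ccccc43)cc2C)C1`, differs from compound 3 in one place: dimethoxymethyl in place of difluoromethyl on a saturated ring carbon. For the measured compounds named here, no pair of measured compounds differs at this position, so the data give no direct guide to the size or direction of the change. The expected step is a 1.6-fold higher number from compound 3 to compound 4 (0.20 log units; within the scatter), small and, if anything, toward a higher number. Compound 4 is therefore estimated at 80 nM in this assay, with a range from 25 nM to 250 nM.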

Compound 4, half-maximal effective concentration: 20 nM
Beside the measured number, compound 4's estimate is 4.0-fold (0.60 log units) above it; measured number below the stated range.
By their numbers in this assay, from the lowest: compounds 4, 2 and 3 (each within the scatter of the next, the first and the last beyond it); then compound 1.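

In this assay, for the compounds shown here, replacing difluoromethyl with dimethoxymethyl on the saturated ring carbon gives a 2.5-fold lower number from compound 3 to compound 4 (0.40 log units; beyond the scatter), the first reading of any change at this position. The number therefore responds to the group on this ring carbon, and the larger dimethoxymethyl group, with its two hydrogen-bond acceptors, is accompanied by a lower number rather than a higher one. No available measurement accounts for this step. The compounds shown leave open whether the oxygens or the larger group matter more. They also leave open how a methoxymethyl, a hydroxymethyl or an amine on this ring carbon would compare.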